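The source may hold more compounds than are shown below. What is called first, only, known or untested is meant among the compounds shown, and "the series" means these compounds.

Series notes. Compound 1 `CC(C)Nc1nc(NCc2ccco2)c2ccc(Cl)cc2n1` is measured in a physicochemical assay for solubility, at pH 2; on this read-out lower numbers stand for lower solubility and higher numbers for higher solubility. In this assay compound 1 gives >= 30000 nM, which is a limit of the assay and not a number. Compound 2 `CC(C)Nc1nc(NCc2ccco2)c2c(Cl)cccc2n1` has the same atoms as compound 1, joined differently; the difference between the two cores is not broken down here. In this assay compound 2 gives >= 30000 nM, again a limit. Compound 3 `Cc1ccc2c(NCc3ccco3)nc(NC(C)C)nc2c1` carries methyl in place of chloro on an aromatic carbon relative to compound 1. In this assay compound 3 gives >= 30000 nM, also a limit. The step that the two limits leave unreadable from compound 1 to compound 3 is unreadable because of the limit of >= 30000 nM in this assay, at which 3 of the 3 values shown sit.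

Compound 4 `Cc1cccc2nc(NC(C)C)nc(NCc3ccco3)c12`, not yet measured, carries methyl in place of chloro on an aromatic carbon relative to compound 2. This is the same kind of change as that from compound 1 to compound 3, but the place differs: in compound 4 the methyl sits ortho to a fused ring and meta to a fused ring, in compound 3 meta to a fused ring and para to a fused ring. The earlier step gives no readable size to carry over. The expected step is a step that the limit leaves unreadable from compound 2 to compound 4, resting on all three measured values sitting at the limit of >= 30000 nM in this assay, at which 3 of the 3 values shown sit. Compound 4 is expected to give 40000 nM in this assay, within 15000 nM to 100000 nM, most likely again as a limit.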

Compound 4, solubility: >= 30000 nM
Compound 4 ended at the assay's limit; the forecaster's own chance of this, stated with the estimate: 80%; the middle value is on the limit's open side.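

No size can be read for the step between compound 2 and compound 4, because both values are limits and not numbers: the limit of >= 30000 nM in this assay, at which 4 of the 4 values shown sit.

The compounds shown leave open whether methyl in place of chloro, at either place on the shared core, changes the read-out in this assay at all.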